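A few compounds are considered here, and "the series" means these few. Any claim that something is new, unique, unknown or untested is made for them only; others in the source may bear on it.

Measured in an in vitro ADME assay on microsomes from liver (Mus musculus) for pharmacokinetics (on this read-out higher numbers stand for fast clearance and lower numbers for slow clearance), so far:
- compound 1 `COc1ccc(CN([C@@H]2CC(F)(F)CCNC2=O)S(=O)(=O)c2ccc(Cl)cc2)cn1` gives 72 mL.min-1.g-1
- compound 2 `O=C(NC1CC1)c1ccc(CN([C@@H]2CC(F)(F)CCNC2=O)S(=O)(=O)c2ccc(Cl)cc2)cc1` gives 2.2 mL.min-1.g-1
- compound 3 `COc1ccc(CN([C@@H]2CC(F)(F)CCNC2=O)S(=O)(=O)c2ccc(Cl)cc2)c(F)c1F` gives 121 mL.min-1.g-1

Of these three, compound 2 stands lowest, beyond the scatter from both others. Compound 4 `CC(C)C1CCNC(=O)C(N(Cc2ccc(C(=O)NC3CC3)cc2)S(=O)(=O)c2ccc(Cl)cc2)C1` differs from it by 5-isopropyl-2-oxoazepan-3-yl in place of 5,5-difluoro-2-oxoazepan-3-yl on a sulfonamide nitrogen and remains unmeasured. Among the measured compounds shown here, the only measured step, a 1.7-fold higher number from compound 1 to compound 3 (0.23 log units; within the scatter), lies within the scatter and changes another group, so it bears on this change only weakly. For the measured compounds named here, compound 2 gives 2.2 mL.min-1.g-1, the lowest value so far, so a rise beyond the scatter is expected in this assay, though no measured step fixes its size. The expected change is a 4.5-fold higher number from compound 2 to compound 4 (0.66 log units; beyond the scatter) for this replacement. For compound 4 the estimated value is 10 mL.min-1.g-1, with an expected range of 3 mL.min-1.g-1 to 40 mL.min-1.g-1 before measurement.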

Compound 4, intrinsic clearance in microsomes: 203 mL.min-1.g-1
Compound 4: middle estimate off by 20-fold (1.31 log units), on the low side; measured number above the stated range.
By their numbers in this assay, from the lowest: compound 2; then compounds 1, 3 and 4 (each within the scatter of the next, the first and the last beyond it).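

In this assay, among the compounds shown here, the replacement on the sulfonamide nitrogen gives a 92-fold higher number from compound 2 to compound 4 (1.97 log units; beyond the scatter), so this position, untouched in the earlier compounds, can move the read-out far beyond the scatter. The entering 5-isopropyl-2-oxoazepan-3-yl has no defined stereocentre while the leaving 5,5-difluoro-2-oxoazepan-3-yl has one, so the step combines both differences. Nothing shown accounts for the size of this step.

Open, going by these compounds, is whether the low number of compound 2 follows the two fluorines or the absence of the isopropyl. A methyl or a single fluorine on the ring at this position would help separate the two.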